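Chloro step from compound 2

The compounds below may be only part of what the source reports. "The series", "measured", "known", "first", "only" and "open" are said of these compounds alone.

In a functional assay on HeLa cells (Homo sapiens) for antiproliferative activity, read by MTT assay, with a stated time of 48 h (a higher number here means a weaker inhibitor, a lower number a stronger inhibitor), compound 1 `CCCn1c(N)c(-c2nc3ccccc3[nH]2)c2nc(C#N)c(C#N)nc21` reads > 50000 nM, which is a limit of the assay. For the measured compounds named here, compound 2 `CCN(CC)CCCCn1c(N)c(-c2nc3ccccc3[nH]2)c2nc(C#N)c(C#N)nc21` gives 10100 nM in this assay, the only actual number so far. Going by the values given here, the single measured step, an at least 4.9-fold lower number from compound 1 to compound 2 (0.69 log units; beyond the scatter), lies on the saturated chain. Compound 3 `CCN(CC)CCCCn1c(N)c(-c2nc3cc(Cl)ccc3[nH]2)c2nc(C#N)c(C#N)nc21` carries chloro in place of hydrogen on an aromatic carbon, giving 5-chloro-1H-benzimidazol-2-yl. Among the compounds with values here, no measured step changes an aromatic carbon. The expected step, a 1.3-fold lower number from compound 2 to compound 3 (0.10 log units; within the scatter), is none beyond the scatter. For compound 3 the estimated value is 8000 nM, with an expected range of 2500 nM to 25000 nM.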

Compound 3, half-maximal inhibitory concentration: 3640 nM
The estimate for compound 3 lay 2.2-fold (0.34 log units) above the measured number; measured number inside the range.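

The aromatic carbon that turns 1H-benzimidazol-2-yl into 5-chloro-1H-benzimidazol-2-yl is a second position that moves the number in this assay beyond the scatter, where earlier only the saturated chain had done so. The change of a single hydrogen to chloro gives a 2.8-fold lower number from compound 2 to compound 3 (0.44 log units; beyond the scatter) and so counts as a modest gain. No measurement shown here accounts for this step.

As far as these compounds go, whether fluoro, methyl, methoxy or an amine at this carbon would act as chloro does remains open. Also open, from the compounds shown here alone, is whether chloro would lift compound 1 off its value of > 50000 nM, which is a limit of the assay.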